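Methoxy for Bromo on the Cinnamate Phenyl Ring

The source may hold more compounds than are shown below. What is called first, only, known or untested is meant among the compounds shown, and "the series" means these compounds.

Three esters sharing one core have been measured in a functional assay on the whole organism (strain Kunming) with Mus musculus as the target, with a stated time of 0.5 h, at a dose of 300 mg/kg by the intraperitoneal route; on this read-out lower numbers stand for a stronger effect and higher numbers for a weaker effect at the one dose given. Compound 1 `COc1ccccc1/C=C/C(=O)OC/C=C/c1cc(OC)c(OC)cc1OC` gives 100%. Compound 2 `COc1cc(OC)c(OC)cc1/C=C/COC(=O)/C=C/c1c(OC)ccc(OC)c1OC` gives 75%. Compound 3 `COc1cc(OC)c(OC)cc1/C=C/COC(=O)/C=C/c1cccc(Br)c1` gives 50%, the lowest of the three numbers and therefore the strongest effect seen so far, since its gaps to compound 2 and to compound 1 both lie beyond the scatter. Among the compounds with values here, the only single-place step measured, a number 50 percentage points lower from compound 1 to compound 3 (beyond the scatter), shows that exchanging a 2-methoxyphenyl for a 3-bromophenyl moved the read-out far downward.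

Compound 4 `COc1cccc(/C=C/C(=O)OC/C=C/c2cc(OC)c(OC)cc2OC)c1` differs from compound 3 in one place: methoxy in place of bromo on an aromatic carbon. This does not simply reverse the measured step. The methoxy now sits meta to a large group rather than where it stood in compound 1, so the earlier step can serve only as a rough guide. Still, a ring bearing a methoxy rather than a bromo went with a far weaker effect in that one comparison, and compound 4 is therefore expected to move back upward, by about a number 25 percentage points higher from compound 3 to compound 4 (beyond the scatter), though by less than the full earlier step. Compound 4 is estimated at 75%, within a range of 50% to 100%.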

Compound 4, a percentage reported as activity, at one dose (the size of the read-out at that dose, not a potency): 75%
The estimate for compound 4 equals the measured number at the digits printed, and the stated range covers the measured number.
By their numbers in this assay, from the lowest: compound 3; then compounds 2 and 4 (each within the scatter of the next); then compound 1.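

Within the data shown here, with the place on the ring held fixed, the change from 3-bromophenyl to 3-methoxyphenyl in this assay gives a number 25 percentage points higher from compound 3 to compound 4 (beyond the scatter) and so isolates the exchange of bromo for methoxy on this aromatic carbon, which no earlier pair had done. The earlier step from compound 1 to compound 3 had changed the group and its place together, whereas the move of the methoxy alone from 2-methoxyphenyl to 3-methoxyphenyl gives a number 25 percentage points lower from compound 1 to compound 4 (beyond the scatter) and shows that the place of the group counts as well as its identity, with both steps printed at the same size and both beyond the scatter. No measurement bearing on these groups is available to explain either step, so the numbers record the changes and nothing more.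

From the compounds shown here alone, whether another group on this aromatic carbon, such as an amine, a carboxylic acid or a trifluoromethyl, would give a number lower still than that of compound 3 remains open. Each read-out also comes from a single dose, so how these esters would compare across a range of doses is left unsettled.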